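Methylating the amino group of compound 2

This account rests on a few compounds, and the source may have more. Where it says the series, first, only, none or still open, it means among the compounds named here.

Compound 2 `Nc1nc2c(nc(N)n2COCCO)c(=O)[nH]1` gives > 500 ug/mL in a functional assay on L1210 cells (Mus musculus) for inhibition (a higher number here means a weaker inhibitor, a lower number a stronger inhibitor), which is a limit of the assay rather than a number (the limit of > 500 ug/mL in this assay, at which 1 of the 2 values shown sits). Compound 1 `Nc1nc2c(nc(Cl)n2COCCO)c(=O)[nH]1` gives 350 ug/mL in this assay. Compound 3 `CNc1nc2c(=O)[nH]c(N)nc2n1COCCO` differs from compound 2 by methyl in place of hydrogen on a nitrogen on an aromatic ring. For the measured compounds named here, the single measured step, an at least 1.4-fold higher number from compound 1 to compound 2 (0.15 log units; that floor lies within the scatter), concerns the exchange of chloro for amino and does not touch this methylation, so for compound 3 no step beyond the scatter is expected. The value of compound 3 is estimated at 600 ug/mL, between 250 ug/mL and 1500 ug/mL, an expected step that the limit leaves unreadable from compound 2 to compound 3 that most likely leaves compound 3 at the limit.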

Compound 3, concentration for 50% inhibition: > 500 ug/mL
Compound 3 gave a limit, no number; the forecaster's own chance of this, stated with the estimate: 75%; the middle value is on the limit's open side.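

Compound 3 is a limit in this assay, as is compound 2, so the step between them cannot be read and methyl in place of hydrogen on this nitrogen yields no number: the limit of > 500 ug/mL in this assay, at which 2 of the 3 values shown sit.

The exchange of chloro for methylamino gives an at least 1.4-fold higher number from compound 1 to compound 3 (0.15 log units; that floor lies within the scatter). A second nitrogen group at this position therefore gives the same reading as amino, with a floor no larger than the scatter.

Still open, as far as these compounds go, is whether a group such as bromo or dimethylamino would move the reading away from compound 1 at 350 ug/mL. Also open, from the compounds shown here alone, is whether ethylamino would give a number rather than a limit.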